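A few compounds are considered here, and "the series" means these few. Any claim that something is new, unique, unknown or untested is made for them only; others in the source may bear on it.

Measured compounds:
- Compound 1 `CCN1C(=O)NC2(CSC3=C2C(=O)c2ccccc2C3=O)C1=O`: 116 nM
- Compound 2 `NCCCN1C(=O)NC2(CSC3=C2C(=O)c2ccccc2C3=O)C1=O`: 25 nM
- Compound 3 `NCCCCN1C(=O)NC2(CSC3=C2C(=O)c2ccccc2C3=O)C1=O`: 35 nM

In a functional assay on MCF7 cells (Homo sapiens) for inhibition (on this read-out lower numbers stand for stronger inhibition and higher numbers for weaker inhibition), compound 3 stands within the scatter of its nearest neighbour, a 1.4-fold higher number from compound 2 to compound 3 (0.15 log units; within the scatter), and well apart from its furthest, a 3.3-fold lower number from compound 1 to compound 3 (0.52 log units; beyond the scatter).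

Compound 4 `CN(C)CCN1C(=O)NC2(CSC3=C2C(=O)c2ccccc2C3=O)C1=O` has the same atoms joined differently: dimethylamino in place of 2-aminoethyl on a saturated chain carbon, two bonds along the chain from an amide-type nitrogen in a ring. Here dimethylamino replaces 2-aminoethyl on a saturated chain carbon, two bonds along the chain from an amide-type nitrogen in a ring.

Among the compounds with values here, no measured step makes this exact change. The closest guides are the modest 4.6-fold lower number from compound 1 to compound 2 (0.67 log units; beyond the scatter) and the much smaller step between the two amino chains already cited. No shift beyond the scatter is therefore expected. The expected change is a 1.1-fold higher number from compound 3 to compound 4 (0.06 log units; within the scatter). For compound 4 the estimated value is 40 nM, with an expected range of 15 nM to 100 nM.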

Compound 4, half-maximal inhibitory concentration: 32 nM
For compound 4 the middle estimate is 1.3-fold (0.10 log units) above the measured one; measured number inside the range.
By their numbers in this assay, from the lowest: compounds 2, 4 and 3 (each within the scatter of the next); then compound 1.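

In this assay, dimethylamino in place of 2-aminoethyl gives little movement (a 1.1-fold lower number from compound 3 to compound 4 (0.04 log units; within the scatter)), so at this place a group with 0 hydrogen-bond donors does as well as one with 1. The 3-aminopropyl chain gives a similar number (a 1.3-fold higher number from compound 2 to compound 4 (0.11 log units; within the scatter)), while the gain over the plain ethyl group holds (a 3.6-fold lower number from compound 1 to compound 4 (0.56 log units; beyond the scatter)). Nothing available explains these numbers. Still open, as far as these compounds go, is how a carboxylic acid, or a morpholine ring at the end of the chain, would fare at this place.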